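Removing one chloro group from compound 2

The source may report more compounds than this note shows. Statements on the series, on what has been measured and on what is new or still open speak of the compounds shown alone.

Values in a functional assay on SW-620 cells (Homo sapiens); a higher number here means a weaker inhibitor of growth, a lower number a stronger inhibitor of growth:
- Compound 1 `O=S(=O)(/C=C/c1ccccc1)Cc1ccc(Nc2ncnc3ccccc23)cc1`: > 100000 nM (a limit of the assay, not a number)
- Compound 2 `O=S(=O)(/C=C/c1ccc(Cl)c(Cl)c1)Cc1ccc(Nc2ncnc3ccccc23)cc1`: 41000 nM
- Compound 3 `CC(C)(C)c1cc(/C=C/S(=O)(=O)Cc2ccc(Nc3ncnc4ccccc34)cc2)cc(C(C)(C)C)c1O`: 9000 nM

Of the two actual numbers, compound 2 at 41000 nM holds the higher, and compound 3 at 9000 nM lies lower by more than the scatter. Compound 4 `O=S(=O)(/C=C/c1ccc(Cl)cc1)Cc1ccc(Nc2ncnc3ccccc23)cc1` is not yet measured. The change is hydrogen in place of chloro on an aromatic carbon, ortho to a chloro group and meta to a large group, so 3,4-dichlorophenyl becomes 4-chlorophenyl.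

Among the compounds with values here, one measured step bears on this: an at least 2.4-fold lower number from compound 1 to compound 2 (0.38 log units; beyond the scatter). On these data alone, it adds both chloro groups at once and starts from a limit, so its full size is unknown and the share of each chloro group cannot be separated. Compound 4 keeps one chloro group, so a partial reversal of that step is expected, giving a modestly higher number in this assay. The expected change is a 1.5-fold higher number from compound 2 to compound 4 (0.17 log units; within the scatter). For compound 4 the estimated value is 60000 nM, with an expected range of 25000 nM to 100000 nM.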

Compound 4, concentration for 50% growth inhibition: 77000 nM
The estimate for compound 4 lay 1.3-fold (0.11 log units) below the measured number; the range from low to high includes it.
By their numbers in this assay, from the lowest: compound 3; then compounds 2 and 4 (each within the scatter of the next). At a limit, above all of these: compound 1.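

Read alone, the loss of this chloro group gives a 1.9-fold higher number from compound 2 to compound 4 (0.27 log units; within the scatter), so in this assay 3,4-dichlorophenyl and 4-chlorophenyl cannot be told apart at this aromatic carbon. Against the phenyl of compound 1, the chloro group that remains gives an at least 1.2-fold lower number from compound 1 to compound 4 (0.11 log units; that floor lies within the scatter), so even this single chloro group is not shown to matter. The value for compound 1 is a limit of the assay and not a number, which leaves the size of that step unknown: the limit of > 100000 nM in this assay, at which 1 of the 4 values shown sits.

Still open, on these data alone, is whether a methoxy group, an amine or a carboxylic acid on this aromatic carbon would read differently from chloro or hydrogen. Also open, as far as these compounds go, is whether the hydroxy group or the tert-butyl groups of compound 3 account for its 9000 nM.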